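This account rests on a few compounds, and the source may have more. Where it says the series, first, only, none or still open, it means among the compounds named here.

Compound 1, `NCC(O)Cn1c(=O)n(C2OC(CO)[C@@H](O)[C@H]2O)c2nc(N)nc(O)c21`: 110%
Compound 2, `C=CCn1c(=S)n(C2OC(COCc3ccccc3)[C@H]3OC(C)(C)O[C@@H]23)c2nc(N)nc(O)c21`: 77%
Compound 3, `C=CCn1c(=O)n([C@H]2CO[C@@H](CO)C2)c2nc(N)nc(O)c21`: 10%

In a functional assay on the whole organism (B cells) with Mus musculus as the target (a higher number here means a larger maximal response, a lower number a smaller maximal response), compound 1 gives 110%, the highest of the three numbers shown. Compound 2 gives 77%, a number lying beyond the scatter below that of compound 1, and compound 3 gives 10%, the furthest from compound 1 and likewise beyond the scatter. For the measured compounds named here, no pair of these measured compounds differs in only one place, so their values show only where each stands and not what any single change does.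

Compound 4 is `Cn1c(=O)n(C2OC(CO)[C@@H](O)[C@H]2O)c2nc(N)nc(O)c21`. It differs from compound 1 in one place: hydrogen in place of 2-amino-1-hydroxyethyl on a saturated chain carbon bound to an aromatic nitrogen. Compound 1 is the only measured anchor for this change, and none of the other measured compounds tells how the chain on that nitrogen shapes the maximal response in this assay. The step from compound 1 to compound 4 is therefore expected to be a decrease of moderate size, beyond the scatter, a number 40 percentage points lower from compound 1 to compound 4 (beyond the scatter), with wide uncertainty. For compound 4 the estimated value in this assay is 70%, within a range from 20% to 115%.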

Compound 4, largest response reached (reported as maximal response), in percent of the reference or control that the assay uses: 99%
For compound 4 the middle estimate is 29 percentage points below the measured one; the measured number falls inside the stated range.
By their numbers in this assay, from the lowest: compound 3; then compound 2; then compound 4; then compound 1.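

For the compounds shown here, the first single-place comparison gives this assay a step of a number 11 percentage points lower from compound 1 to compound 4 (beyond the scatter), a modest loss that nonetheless lies beyond the scatter. The 3-amino-2-hydroxypropyl chain on this aromatic nitrogen therefore adds to the maximal response, but it is not needed for a high one: with only methyl at this position, compound 4 still gives 99%. No measurement here accounts for the step.

On these data alone, it remains open which part of the chain carries the difference, since a 3-aminopropyl chain or a 2-hydroxypropyl chain would separate the amine from the hydroxyl. It is also unclear whether a carboxylic acid or a longer plain alkyl chain at this position would raise or lower the response.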